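The source may hold more compounds than are shown below. What is called first, only, known or untested is meant among the compounds shown, and "the series" means these compounds.

Among the measured compounds shown here, compound 2, `CCCCOc1ccc(-c2nc3ncccn3c2NCc2ccc(OC)cc2)cc1`, is the one compound here with a measured number: in a toxicity assay on A549 cells (Homo sapiens) for cytotoxicity, read by luminescence and CellTiter-Glo, with a stated time of 48 h (on this read-out lower numbers stand for higher toxicity in this test and higher numbers for lower toxicity in this test), compound 2 gives 55000 nM. Compound 1, `CCCCOc1ccc(-c2nc3ncccn3c2NCCC)cc1`, differs from it only in the group on the saturated chain carbon bound to a nitrogen on an aromatic ring. In this assay compound 1 reached only the limit of the test, > 100000 nM, which is the limit of > 100000 nM in this assay, at which 1 of the 2 values shown sits. For the measured compounds named here, the one measured step, an at least 1.8-fold lower number from compound 1 to compound 2 (0.25 log units; that floor lies within the scatter), therefore gives only a floor, and that floor sits inside the scatter, so it tells little about how much this position matters. Compound 3, `CCCCOc1ccc(-c2nc3ncccn3c2NCc2c[nH]cn2)cc1`, is not yet measured. It differs from compound 2 in one place: 1H-imidazol-4-yl in place of 4-methoxyphenyl on a saturated chain carbon bound to a nitrogen on an aromatic ring. Going by the values given here, no measured step covers this exchange of one ring for another at that position, and the single step that touches the position is small. Compound 3 is therefore expected to stay close to compound 2, with the step of a 1.5-fold higher number from compound 2 to compound 3 (0.16 log units; within the scatter) foreseen as no larger than the scatter. The estimate for compound 3 is 80000 nM, with a range from 30000 nM to 200000 nM.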

Compound 3, half-maximal cytotoxic concentration: > 100000 nM
Compound 3: a limit, no number; the forecaster's own chance of this, stated with the estimate: 45%; middle value at least 1.2-fold (0.09 log units) from the limit.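

In this assay, 1H-imidazol-4-yl in place of 4-methoxyphenyl gives an at least 1.8-fold higher number from compound 2 to compound 3 (0.25 log units; that floor lies within the scatter), so this exchange, like the earlier one at the same position, yields only a floor and not a measured size. Having a ring at this position is therefore not enough for a number to appear in this test, as compound 3 stands at a limit, not a number. The step between compound 1 and compound 3 cannot be read, since both end at the same limit, and most of this small set now rests there: the limit of > 100000 nM in this assay, at which 2 of the 3 values shown sit.

On these data alone, whether compound 2 truly differs from compound 1 or compound 3 stays open, as both readable steps are floors inside the scatter. Also open, as far as these compounds go, is what a phenyl ring, an amine, a carboxylic acid or a longer chain would give at this position.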